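A few compounds are considered here, and "the series" means these few. Any claim that something is new, unique, unknown or untested is made for them only; others in the source may bear on it.

Compound 1 `Nc1ccc2cccc(OC3CCC3)c2n1`: > 2000 nM
Compound 2 `CCOCCOc1cccc2ccc(N)nc12`: > 2000 nM

The two measured compounds share a core and differ only in the group on the ring oxygen. In an assay on cells with melanin-concentrating hormone receptor 1 (Homo sapiens) as the target, read by radioligand binding (a higher number here means a weaker inhibitor, a lower number a stronger inhibitor), compound 1 gives > 2000 nM, which is a limit of the assay and not a number. Compound 2 in this assay gives > 2000 nM, again a limit rather than a number. The step that the two limits leave unreadable from compound 1 to compound 2 is thus unreadable in size and direction, because the limit of > 2000 nM in this assay, at which 2 of the 2 values shown sit, covers both values. Compound 3 `Nc1ccc2cccc(OCC3CCCC3)c2n1` has not been measured; it differs from compound 2 by cyclopentyl in place of ethoxymethyl on a saturated chain carbon bound to an oxygen on an aromatic ring. Going by the values given here, the only measured step that bears on this change is a step that the two limits leave unreadable from compound 1 to compound 2, and it gives no readable size, so no step beyond the scatter can be expected in either direction. The step from compound 2 to compound 3 is therefore estimated as a step that the limit leaves unreadable from compound 2 to compound 3. Compound 3 is expected to come out at 3000 nM, within a range from 800 nM to 12000 nM, most likely as a further limit.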

Compound 3, half-maximal inhibitory concentration: 53 nM
For compound 3 the middle estimate is 57-fold (1.75 log units) above the measured one, and the stated range ends above it.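

In this assay, the group on the ring oxygen can bring the shared core to a measurable value: cyclopentylmethyl gives an at least 37-fold lower number from compound 2 to compound 3 (1.57 log units; beyond the scatter), and an at least 37-fold lower number from compound 1 to compound 3 (1.57 log units; beyond the scatter). The second step shows that a carbon ring on the oxygen is not enough by itself, as compound 1 carries cyclobutyl there and stays at a limit of the assay. Both sizes are only lower bounds, and the step between compound 1 and compound 2 cannot be read, because those two compounds sit at that limit: the limit of > 2000 nM in this assay, at which 2 of the 3 values shown sit.

The compounds shown leave open whether the larger ring or the saturated chain carbon that links it to the oxygen accounts for the change from cyclobutyl to cyclopentylmethyl. They also leave open how cyclohexylmethyl, benzyl or a chain ending in an amine would read at this oxygen.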